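A few compounds are considered here, and "the series" means these few. Any claim that something is new, unique, unknown or untested is made for them only; others in the source may bear on it.

Measured compounds:
- compound 1, `Cc1cc(O)cc(-c2nn(CC#N)cc2-c2ccnc(-c3ccc(Oc4ccccc4)cc3)c2)c1`, giving 86% in a functional assay on T47D cells (Homo sapiens) for cytotoxicity, read by sulforhodamine B assay, with a stated time of 48 h, tested at 0.01 uM; on this read-out higher numbers stand for a weaker effect at the one concentration tested and lower numbers for a stronger effect
- compound 2, `COc1cc(C)cc(-c2nn(CC#N)cc2-c2ccnc(-c3ccc(N(C)C)cc3)c2)c1`, giving 104% in this assay

Of these two numbers compound 2 holds the higher one; compound 1 stands lower, a gap beyond the usual scatter. Compound 3, `Cc1cc(O)cc(-c2nn(CC#N)cc2-c2ccnc(-c3ccc(N(C)C)cc3)c2)c1`, has not yet been measured. It differs from compound 2 by hydrogen in place of methyl on an oxygen on an aromatic ring. Among the compounds with values here, no comparable step between measured compounds is available, so a small change is expected in this assay, if any beyond the scatter, at most a slight lowering: the step from compound 2 to compound 3 is estimated as a number 8 percentage points lower from compound 2 to compound 3 (within the scatter). For compound 3 the value in this assay is estimated at 96%, with a range from 80% to 110%.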

Compound 3, a percentage reported as activity, at one concentration (the size of the read-out at that concentration, not a potency): 90%
Estimate against measurement, compound 3: 6 percentage points above, within the range that was stated.
By their numbers in this assay, from the lowest: compounds 1 and 3 (each within the scatter of the next); then compound 2.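

In this assay, within the data shown here, the change from methoxy to hydroxy gives a number 14 percentage points lower from compound 2 to compound 3 (beyond the scatter), the first single-place evidence that the group on this oxygen affects the read-out at the one concentration tested. With hydroxy in place, dimethylamino instead of phenoxy gives a number 4 percentage points higher from compound 1 to compound 3 (within the scatter), so this pair does not separate those two groups. Nothing available explains either step.

As far as these compounds go, it remains open whether the methoxy-to-hydroxy step would recur with phenoxy on the core. From the compounds shown here alone, it is also open how an ethoxy group or an amine in place of the hydroxy would read.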